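Aryl Ether Variant of the Diaminoquinoxaline Core

The source may report more compounds than this note shows. Statements on the series, on what has been measured and on what is new or still open speak of the compounds shown alone.

Compound 1 `Nc1cc(N)c2nc(-c3ccccc3)c(NCc3ccc(F)cc3)nc2c1` gives 28200 nM in a functional assay on NCI/ADR-RES cells (Homo sapiens) for inhibition, read by sulforhodamine B assay, with a stated time of 48 h; a higher number here means that more compound is tolerated, a lower number that less compound is tolerated.
Compound 2 `COc1ccc(Sc2nc3cc(N)cc(N)c3nc2-c2ccccc2)cc1` gives only a limit, < 100000 nM, in this assay.

For compound 2 the value in this assay is a limit, not a number, as noted in the limit of < 100000 nM in this assay, at which 1 of the 2 values shown sits. The step from compound 1 to compound 2 is therefore unreadable: a step that the limit leaves unreadable from compound 1 to compound 2. Compound 3 `Nc1cc(N)c2nc(-c3ccccc3)c(Oc3ccc(F)cc3)nc2c1` differs from compound 2 by 4-fluorophenoxy in place of (4-methoxyphenyl)sulfanyl on an aromatic carbon. Within the data shown here, no measured step in this assay bears on this change in readable form, so the direction and size of the step to compound 3 cannot be taken from the data. Compound 3 is expected to lie near compound 1 at 30000 nM, within 8000 nM to 100000 nM, which means an estimated step that the limit leaves unreadable from compound 2 to compound 3.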

Compound 3, concentration lethal to 50% of the cells: 70800 nM
Beside the measured number, compound 3's estimate is 2.4-fold (0.37 log units) below it; low and high end bracket the measured number.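

In this assay, among these compounds, 4-fluorophenoxy in place of (4-fluorobenzyl)amino gives a 2.5-fold higher number from compound 1 to compound 3 (0.40 log units; beyond the scatter), the first readable change at this position, on an aromatic carbon next to the ring nitrogen. More of compound 3 is thus tolerated than of compound 1. Steps involving compound 2 cannot be read, because compound 2 has only a limit: the limit of < 100000 nM in this assay, at which 1 of the 3 values shown sits.

The compounds shown leave open whether the step follows from the oxygen link replacing the amino link or from the shorter connection to the fluorophenyl ring. They also leave open how a (4-fluorophenyl)sulfanyl group or a carboxylic acid would behave here.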